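Methoxy on the Phenyl Tail of a Ceramidase Inhibitor

The compounds below may be only part of what the source reports. "The series", "measured", "known", "first", "only" and "open" are said of these compounds alone.

Going by the values given here, compound 1, `O=C(NCCCCc1ccccc1)n1c(=O)oc2ccccc21`, is the only compound here with a number. In an assay on HEK293 cells for inhibition of acid ceramidase (Homo sapiens), with a stated time of 10 min (on this read-out higher numbers stand for weaker inhibition and lower numbers for stronger inhibition), compound 1 gives 64 nM, so on the numbers shown compound 1 stands alone at the top, with nothing to rank it against. Among the compounds with values here, a second compound, compound 2, `Cc1cccc2oc(=O)n(C(=O)NCCCCc3ccccc3)c12`, carries a methyl group on the shared core, but in this assay the entry for compound 2 reads no result reported, so no number is available for it and no step between measured compounds can be drawn.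

Compound 3, `COc1ccc(CCCCNC(=O)n2c(=O)oc3ccccc32)cc1`, keeps the core and the four-carbon chain of compound 1 and alters only the phenyl ring at the far end. The change is methoxy in place of hydrogen on an aromatic carbon, para to a large group. Nothing measured in this series shows what such a change does. The expectation is therefore a modest step, most likely within the scatter, a 1.2-fold lower number from compound 1 to compound 3 (0.07 log units; within the scatter), since a small group at the outer end of the chain often leaves potency close to where it was. Compound 3 is estimated at 55 nM, with a range from 15 nM to 200 nM.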

Compound 3, half-maximal inhibitory concentration: 63 nM
The estimate for compound 3 lay 1.1-fold (0.06 log units) below the measured number; measured number inside the range.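

In this assay, going by these compounds alone, the step is a 1.0-fold lower number from compound 1 to compound 3 (0.01 log units; within the scatter), the only step between measured compounds, and it gives the far end of the molecule its first reading. Going from phenyl to 4-methoxyphenyl adds 2 heavy atoms, 1 carbon and 1 oxygen, on an aromatic carbon at the end of the four-carbon chain, yet the two compounds cannot be told apart in this assay, so this position accepts a methoxy with no loss of inhibition that rises above the usual scatter. Nothing available explains why the two compounds read alike.

On these data alone, one substituent at one place says little about the ring as a whole, so it stays open whether a carboxylic acid, an amine or a chlorine in the same place would also leave the number unchanged, and whether a methoxy elsewhere on this ring would. A longer chain between the core and the phenyl ring is equally untested here, and the methyl group on the shared core of compound 2 remains unread, with no number to compare.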